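Swapping a Ring Amine for an Open-Chain Amine

This account rests on a few compounds, and the source may have more. Where it says the series, first, only, none or still open, it means among the compounds named here.

Compound 3 `Cc1ccc2nc(/N=C3\C(=O)N(CN4CCCCC4)c4cccc(Br)c43)sc2c1` and compound 1 `CCN(CC)CN1C(=O)/C(=N\c2nc3ccc(C)cc3s2)c2c(Br)cccc21` share one core and differ in a single place: diethylamino in place of piperidin-1-yl on a saturated chain carbon bound to an amide-type nitrogen in a ring. In a functional assay on MCF7 cells (Homo sapiens) for cytotoxicity, read by sulforhodamine B assay, with a stated time of 48 h (a higher number here means a weaker inhibitor of growth, a lower number a stronger inhibitor of growth), compound 3 gives 39100 nM and compound 1 gives 30200 nM, giving a 1.3-fold lower number from compound 3 to compound 1 (0.11 log units; within the scatter). Compound 2 `O=C1C(=O)N(CN2CCCCC2)c2cccc(Cl)c21` rests on another core; the difference between the two cores is not broken down here. In this assay compound 2 gives 51200 nM, a number close to those of compound 3 and compound 1. Compound 4 `CCN(CC)CN1C(=O)C(=O)c2c(Cl)cccc21` is not yet measured and carries the same change on the core of compound 2: diethylamino in place of piperidin-1-yl on a saturated chain carbon bound to an amide-type nitrogen in a ring. Because the measured step of a 1.3-fold lower number from compound 3 to compound 1 (0.11 log units; within the scatter) stayed within the scatter, the step now expected is a 1.3-fold lower number from compound 2 to compound 4 (0.11 log units; within the scatter). For compound 4 in this assay the estimate is 40000 nM, expected between 20000 nM and 80000 nM.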

Compound 4, concentration for 50% growth inhibition: 34100 nM
Beside the measured number, compound 4's estimate is 1.2-fold (0.07 log units) above it; the range from low to high includes it.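

On the core of compound 2, diethylamino in place of piperidin-1-yl gives a 1.5-fold lower number from compound 2 to compound 4 (0.18 log units; within the scatter) in this assay. The same change on the two cores gives steps that agree: the same change on two cores in this assay, a 1.3-fold lower number (0.11 log units; within the scatter) from compound 3 to compound 1 and a 1.5-fold lower number (0.18 log units; within the scatter) from compound 2 to compound 4, 1.2-fold (0.06 log units) apart, within the scatter of two such steps. Each step stays within the scatter, so the swap makes no clear difference on either core, and neither amine can be called the better one, while two pairs set no rule for the whole series.

The compounds shown leave open what other amines on the same chain carbon would do, such as morpholin-4-yl or dimethylamino. They also leave open whether a longer chain between the ring nitrogen and the amine would give a step beyond the scatter.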